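The source may report more compounds than this note shows. Statements on the series, on what has been measured and on what is new or still open speak of the compounds shown alone.

Going by the values given here, in an assay for inhibition of inositol hexakisphosphate kinase 3 (Homo sapiens), read by colorimetric assay, coupled enzyme assay and malachite green, with a stated time of 120 min, in the presence of a further agent that is not named here (on this read-out higher numbers stand for weaker inhibition and lower numbers for stronger inhibition), compound 2 `O=C(O)c1ccc2noc(-c3ccc(N4CCCC4=O)cc3)c2c1` gives 2170 nM, the highest of the two numbers measured so far. Among the compounds with values here, the only other compound, compound 1 `O=C(O)c1ccc2noc(-c3ccc(Cc4ccccc4)cc3)c2c1`, gives 1290 nM, and the step of a 1.7-fold higher number from compound 1 to compound 2 (0.23 log units; within the scatter) falls within the ordinary scatter of repeated measurements. Compound 3 `O=C(O)c1ccc2noc(-c3ccc(NC(=O)c4ccccc4)cc3)c2c1` has not yet been measured; it differs from compound 2 in one place: benzamido in place of 2-oxopyrrolidin-1-yl on an aromatic carbon. Within the data shown here, the one measured step that bears on this change, a swap of the group on the same aromatic carbon, was the step just named and did not leave the scatter. Benzamido carries the aromatic ring found in the benzyl of compound 1 together with the carbonyl and nitrogen found in the 2-oxopyrrolidin-1-yl of compound 2, so no step beyond the scatter is expected in either direction. Compound 3 is expected to give about 1600 nM in this assay, an estimated step of a 1.4-fold lower number from compound 2 to compound 3 (0.13 log units; within the scatter) with a likely range from 500 nM to 5000 nM.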

Compound 3, half-maximal inhibitory concentration: 200 nM
Compound 3: the middle estimate sits 8.0-fold (0.90 log units) above what was measured, and the stated range ends above it.
By their numbers in this assay, from the lowest: compound 3; then compounds 1 and 2 (each within the scatter of the next).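

Swapping the group on this aromatic carbon, para to a large group, had so far stayed within the scatter, but in this assay benzamido gives an 11-fold lower number from compound 2 to compound 3 (1.04 log units; beyond the scatter), so the choice of group here can matter a great deal. Benzamido also beats benzyl, with a 6.5-fold lower number from compound 1 to compound 3 (0.81 log units; beyond the scatter): among these three compounds, the group that has both a six-membered aromatic ring and an amide hydrogen goes with the strongest inhibition, while benzyl has the ring and 2-oxopyrrolidin-1-yl has the carbonyl and nitrogen without a hydrogen-bond donor. Nothing measured here explains why this change lowers the number.

Whether the ring, the amide hydrogen or both account for the drop stays open: acetamido would keep the amide without the ring, and N-methylbenzamido would keep the ring without the amide hydrogen. Also open, as far as these compounds go, is how a further group on the benzamido ring, such as methoxy or chlorine, would change the number.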